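Removing One Methoxy Group: Expected Effect on Growth Inhibition

The source may report more compounds than this note shows. Statements on the series, on what has been measured and on what is new or still open speak of the compounds shown alone.

Compound 1 `COc1cc(-c2cc(/C=C/C(=O)c3ccc(N)cc3)[nH]n2)cc(OC)c1OC` gives 65800 nM in a functional assay on NCI/ADR-RES cells (Homo sapiens) for inhibition, read by sulforhodamine B assay, with a stated time of 48 h; a lower number here means a stronger inhibitor of growth, a higher number a weaker inhibitor of growth.
Compound 2 `COc1cc(-c2cc(/C=C/C(=O)c3ccc(Cl)c(Cl)c3)[nH]n2)cc(OC)c1OC` gives only the assay limit > 100000 nM.
Compound 3 `COc1ccc(C(=O)/C=C/c2cc(-c3cc(OC)c(OC)c(OC)c3)n[nH]2)cc1OC` gives 15700 nM.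

Compound 3 has the lowest of the two numbers; its nearest neighbour is compound 1, separated by a 4.2-fold lower number from compound 1 to compound 3 (0.62 log units; beyond the scatter). The next compound, compound 4 `COc1ccc(C(=O)/C=C/c2cc(-c3cc(OC)c(OC)c(OC)c3)n[nH]2)cc1`, differs by hydrogen in place of methoxy on an aromatic carbon. The measured steps, a 4.2-fold lower number from compound 1 to compound 3 (0.62 log units; beyond the scatter) and an at least 6.3-fold lower number from compound 2 to compound 3 (0.80 log units; beyond the scatter), all replace the whole aryl group on the carbonyl carbon; none removes a single methoxy group, so they bear only loosely on this change. A small loss or no change beyond the scatter seems most likely, and the step is estimated as a 1.6-fold higher number from compound 3 to compound 4 (0.20 log units; within the scatter). Compound 4 is expected to give 25000 nM, in the range 10000 nM to 70000 nM.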

Compound 4, concentration for total growth inhibition: 9850 nM
The estimate for compound 4 lay 2.5-fold (0.40 log units) above the measured number, and the stated range ends above it.
By their numbers in this assay, from the lowest: compounds 4 and 3 (each within the scatter of the next); then compound 1. At a limit, above all of these: compound 2.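

In this assay, a 1.6-fold lower number from compound 3 to compound 4 (0.20 log units; within the scatter), so the methoxy group on this aromatic carbon can go without a change beyond the scatter, and 4-methoxyphenyl serves as well as 3,4-dimethoxyphenyl. The other aryl comparisons also hold with this single methoxy group: a 6.7-fold lower number from compound 1 to compound 4 (0.82 log units; beyond the scatter), and an at least 10-fold lower number from compound 2 to compound 4 (1.00 log units; beyond the scatter). The value of compound 2 is a limit, so that last step is only a floor: the limit of > 100000 nM in this assay, at which 1 of the 4 values shown sits.

Still open, from the compounds shown here alone, is what a hydroxyl group or a fluorine atom would give on this same carbon. Whether the remaining methoxy group matters also stays open, since a plain phenyl on the carbonyl carbon is not among the compounds shown.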